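Working notes: one aromatic substituent varied on the shared core

The source may report more compounds than this note shows. Statements on the series, on what has been measured and on what is new or still open speak of the compounds shown alone.

Measured compounds:
- compound 1, `Cc1c(C(C)OC(=O)Nc2ccccc2)oc2nc(C3CC3)nn12`, in a functional assay on CHO cells for antagonist activity at metabotropic glutamate receptor 5 (Homo sapiens), read by calcium flux (a lower number here means a stronger inhibitor, a higher number a weaker inhibitor), compound 1 gives 12.6 nM
- compound 2, `Cc1c(C(C)OC(=O)Nc2ccccc2)oc2nc(-c3cccs3)nn12`, compound 2 gives 7.94 nM
- compound 3, `Cc1c(C(C)OC(=O)Nc2ccccc2)oc2nc(-c3ccc(F)cc3)nn12`, compound 3 gives 10 nM

Compound 3 stands second highest of the three numbers. Its neighbours lie close: the step of a 1.3-fold higher number from compound 2 to compound 3 (0.10 log units; within the scatter) and the step of a 1.3-fold lower number from compound 1 to compound 3 (0.10 log units; within the scatter) are both within the scatter, so no order among the three can be read.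

Compound 4, `Cc1nc2oc(C(C)OC(=O)Nc3ccccc3)c(C)n2n1`, is not yet measured. It differs from compound 3 in one place: methyl in place of 4-fluorophenyl on an aromatic carbon.

Going by the values given here, the steps that bear on this position are a 1.6-fold lower number from compound 1 to compound 2 (0.20 log units; within the scatter), a 1.3-fold lower number from compound 1 to compound 3 (0.10 log units; within the scatter) and a 1.3-fold higher number from compound 2 to compound 3 (0.10 log units; within the scatter); each is within the scatter, and the position has so far accepted cyclopropyl, thiophen-2-yl and 4-fluorophenyl alike. As far as these compounds go, none of them involves methyl, so the move to the smallest group is untested. Given that the measured exchanges changed little, the expected step is a 2.0-fold higher number from compound 3 to compound 4 (0.30 log units; within the scatter), a slight rise if any, at or just beyond the scatter. For compound 4 the estimated value in this assay is 20 nM, with a range from 6 nM to 80 nM.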

Compound 4, half-maximal inhibitory concentration: 39.8 nM
Estimate against measurement, compound 4: 2.0-fold (0.30 log units) below; the measured number falls inside the stated range.
By their numbers in this assay, from the lowest: compounds 2, 3 and 1 (each within the scatter of the next); then compound 4.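

In this assay, going by these compounds alone, methyl is the first group at this position, on an aromatic carbon between two ring nitrogen atoms, to move the number beyond the scatter (a 4.0-fold higher number from compound 3 to compound 4 (0.60 log units; beyond the scatter)) and (a 5.0-fold higher number from compound 2 to compound 4 (0.70 log units; beyond the scatter)) and (a 3.2-fold higher number from compound 1 to compound 4 (0.50 log units; beyond the scatter)). The position therefore does not accept every group alike: cyclopropyl, thiophen-2-yl and 4-fluorophenyl, though not ordered among themselves, each give a lower number than methyl, and none of the four compounds goes against this. No measurement at hand explains this rise.

With methyl the only group here that has no ring, the compounds shown cannot tell whether a ring as such matters or whether an open chain such as ethyl or n-butyl would fall with the ring-bearing groups. As far as these compounds go, an amine or a carboxylic acid at this carbon also remains open, as does whether the same step would hold with a different carbamate side chain.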